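The source may hold more compounds than are shown below. What is called first, only, known or untested is meant among the compounds shown, and "the series" means these compounds.

Values so far in a functional assay on DU-145 cells (Homo sapiens) for inhibition, read by MTT assay, with stated times of 18 h and 4 h; a lower number here means a stronger inhibitor, a higher number a weaker inhibitor
compound 1 `CCCCCCCCCCOP(=O)(O)OCCSC(=S)N1CCCCCC1` gives 24000 nM
compound 2 `CCCCCCCCCCOP(=O)(O)OCCSC(=S)N1CCCC1` gives 46100 nM
compound 3 `CCCCCCCCCCCCCCCCOP(=O)(O)OCCSC(=S)N1CCN(C)CC1` gives 49300 nM

Compound 3 lies within the scatter of compound 2 and beyond the scatter of compound 1, which has the lower number. Compound 4 `CCCCCCCCCCOP(=O)(O)OCCSC(=S)N1CCN(C)CC1` keeps the rest of compound 3 and differs only in the chain (hydrogen in place of hexyl on a saturated chain carbon, ten or more bonds along the chain from an oxygen on an unsaturated carbon). For the measured compounds named here, no measured step changes the chain. Going by the values given here, the one measured step (a 1.9-fold higher number from compound 1 to compound 2 (0.28 log units; within the scatter)) changes the ring on the thiocarbonyl carbon and bears on this change only indirectly, as it shows little movement among compounds with the chain of compound 4. Compound 1 (24000 nM) and compound 2 (46100 nM) both carry that chain, and their values are close to that of compound 3, so no large shift is expected. The expected step (a 1.2-fold lower number from compound 3 to compound 4 (0.07 log units; within the scatter)) stays within the scatter, with only a slight lean towards a lower number. For compound 4 the estimated value is 42000 nM (expected range 18000 nM to 100000 nM).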

Compound 4, half-maximal inhibitory concentration: 82300 nM
Beside the measured number, compound 4's estimate is 2.0-fold (0.29 log units) below it; low and high end bracket the measured number.
By their numbers in this assay, from the lowest: compounds 1, 2, 3 and 4 (each within the scatter of the next, the first and the last beyond it).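

In this assay the chain now has a measured step: hydrogen in place of hexyl on a saturated chain carbon gives a change that stays within the scatter (a 1.7-fold higher number from compound 3 to compound 4 (0.22 log units; within the scatter)), so this pair with the 4-methylpiperazin-1-yl group does not separate the two chains. For the compounds shown here, on the thiocarbonyl carbon, 4-methylpiperazin-1-yl in place of pyrrolidin-1-yl also stays within the scatter (a 1.8-fold higher number from compound 2 to compound 4 (0.25 log units; within the scatter)), while in place of azepan-1-yl it gives the only new step beyond the scatter, and a modest one (a 3.4-fold higher number from compound 1 to compound 4 (0.54 log units; beyond the scatter)). No measured evidence is at hand to explain these values.

Going by these compounds alone, only one pair carries the chain change, so whether the step holds with azepan-1-yl or pyrrolidin-1-yl stays open. On these data alone, how this assay reads a longer chain, or a chain carrying a carboxylic acid, also stays open.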